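The compounds below may be only part of what the source reports. "The series", "measured", "known", "first", "only" and "open" are said of these compounds alone.

Measured compounds:
compound 1, `COc1cc(C(=O)/C=C/c2c[nH]c3ccccc23)cc(SC)c1OC`, 159 nM;
compound 2, `COc1cc(C(=O)/C(C)=C/c2c[nH]c3ccccc23)cc([Se]C)c1OC`, 34 nM;
compound 3, `COc1cc(C(=O)/C=C/c2cn(C)c3ccccc23)cc(SC)c1OC`, 105 nM.

In a functional assay on HeLa cells (Homo sapiens) for antiproliferative activity, read by MTT assay, with a stated time of 48 h (a higher number here means a weaker inhibitor, a lower number a stronger inhibitor), compound 1 gives 159 nM, while compound 3 gives 105 nM. The change between them is methyl in place of hydrogen on an aromatic nitrogen, and the step it made is a 1.5-fold lower number from compound 1 to compound 3 (0.18 log units; within the scatter). Compound 2, with 34 nM, stands lowest of the three; how the core of compound 2 differs from the core of compound 1 is not broken down here. Compound 4, `COc1cc(C(=O)/C(C)=C/c2cn(C)c3ccccc23)cc([Se]C)c1OC`, has not yet been measured in this assay. It differs from compound 2 by methyl in place of hydrogen on an aromatic nitrogen, the same kind of change as from compound 1 to compound 3. Resting on the step of a 1.5-fold lower number from compound 1 to compound 3 (0.18 log units; within the scatter), a step of about a 1.2-fold lower number from compound 2 to compound 4 (0.08 log units; within the scatter) is expected. Compound 4 is therefore estimated at 28 nM, expected within 12 nM to 70 nM.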

Compound 4, half-maximal inhibitory concentration: 63 nM
Beside the measured number, compound 4's estimate is 2.3-fold (0.35 log units) below it; measured number inside the range.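

In this assay methyl in place of hydrogen on an aromatic nitrogen gives a 1.9-fold higher number from compound 2 to compound 4 (0.27 log units; within the scatter) and, set beside the earlier step, this shows that the change does not carry over as one fixed step from one core to the other: the same change on two cores in this assay, a 1.5-fold lower number (0.18 log units; within the scatter) from compound 1 to compound 3 and a 1.9-fold higher number (0.27 log units; within the scatter) from compound 2 to compound 4, 2.8-fold (0.45 log units) apart, beyond the scatter of two such steps. Each step taken alone lies within the scatter, so neither core by itself shows a clear effect of the methyl. Only the gap between the two steps stands beyond the scatter, and two cores cannot show which part of them goes with that gap or why it arises.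

On these data alone, whether the same change would run alike on further cores remains open. So does how an ethyl group, a longer chain or a chain ending in an amine on that nitrogen would read.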